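From quinolin-8-yl to 1,3-thiazolidin-4-yl on the carbonyl carbon

A few compounds are considered here, and "the series" means these few. Any claim that something is new, unique, unknown or untested is made for them only; others in the source may bear on it.

Values in an ADME assay on HepG2 cells (Homo sapiens) for cytotoxicity; on this read-out higher numbers stand for lower toxicity in this test and lower numbers for higher toxicity in this test:
- compound 1 `O=C(N[C@H](/C=C/S(=O)(=O)c1ccccc1)CCc1ccccc1)c1cccc2cccnc12`: > 80000 nM (a limit)
- compound 2 `CC(C)C[C@@H](/C=C/S(=O)(=O)c1ccccc1)NC(=O)c1cccc2cccnc12`: 15100 nM
- compound 3 `O=C(NC/C=C/S(=O)(=O)c1ccccc1)c1cccc2cccnc12`: 55500 nM
- compound 4 `O=C(N[C@H](/C=C/S(=O)(=O)c1ccccc1)CCc1ccccc1)[C@@H]1CSCN1`: not yet measured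

Compound 1 stands at the limit of > 80000 nM in this assay, at which 1 of the 3 values shown sits. That is a limit and not a number.

Compound 4 differs from compound 1 in one place: 1,3-thiazolidin-4-yl in place of quinolin-8-yl on a carbonyl carbon. In words, 1,3-thiazolidin-4-yl stands in place of quinolin-8-yl on a carbonyl carbon.

Among the measured compounds shown here, no measured step touches this place. All three change the group on a saturated chain carbon: an at least 5.2-fold lower number from compound 1 to compound 2 (0.72 log units; beyond the scatter), an at least 1.4-fold lower number from compound 1 to compound 3 (0.15 log units; that floor lies within the scatter) and a 3.7-fold higher number from compound 2 to compound 3 (0.57 log units; beyond the scatter). They bear on the new change only indirectly, as a gauge of how far one change has moved this read-out in the series, and they give no direction for it.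

The expectation rests on compound 4 keeping the phenethyl chain of compound 1, whose limit is > 80000 nM. A step of modest size to a lower number in this assay is expected, or none beyond the scatter. The estimated step is an at least 1.4-fold lower number from compound 1 to compound 4 (0.16 log units; that floor lies within the scatter). For compound 4 the expected value is 55000 nM, with an estimated range of 18000 nM to 160000 nM.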

Compound 4, half-maximal cytotoxic concentration: 77800 nM
The estimate for compound 4 lay 1.4-fold (0.15 log units) below the measured number, within the range that was stated.
By their numbers in this assay, from the lowest: compound 2; then compounds 3 and 4 (each within the scatter of the next). At a limit, above all of these: compound 1.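

Quinolin-8-yl on the carbonyl carbon is exchanged here for the first time: in this assay the change to 1,3-thiazolidin-4-yl gives an at least 1.0-fold lower number from compound 1 to compound 4 (0.01 log units; that floor lies within the scatter). Compound 1 stands at a limit and not at a number: the limit of > 80000 nM in this assay, at which 1 of the 4 values shown sits. With the phenethyl chain kept, compound 4 gives a true number of 77800 nM, so a number of this height does not require quinolin-8-yl, and the smaller 1,3-thiazolidin-4-yl group, with its sulfur and its hydrogen-bond donor, is tolerated at this place in this assay.

Going by these compounds, how large the step really is remains open beyond that floor, as does whether the same exchange would read alike with the isobutyl chain of compound 2 or the hydrogen of compound 3. Also open, on these data alone, is how this assay would read with a longer chain carrying an amine on the carbonyl carbon, which would show whether a ring is needed at this place at all.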